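Methoxy to trifluoromethyl on the indole aryl: second instance

The compounds below may be only part of what the source reports. "The series", "measured", "known", "first", "only" and "open" are said of these compounds alone.

Measured compounds:
compound 1, `CCCCc1ccc2[nH]c(-c3ccc(OC)cc3)c(/C=N/NC(=O)c3ccc(Cl)cc3)c2c1`, 220 nM
compound 2, `CCCCc1ccc2[nH]c(-c3ccc(C(F)(F)F)cc3)c(/C=N/NC(=O)c3ccc(Cl)cc3)c2c1`, 1060 nM
compound 3, `CCCCc1ccc2[nH]c(-c3ccc(OC)cc3)c(/C=N/NC(=O)c3ccccn3)c2c1`, 160 nM

All three numbers come from a functional assay on MCF7 cells (Homo sapiens) for antiproliferative activity, with a stated time of 5 days; on this read-out lower numbers stand for stronger inhibition and higher numbers for weaker inhibition. Compound 1 gives 220 nM in this assay and serves as the reference for both changes made so far. From compound 1 to compound 2 the change is trifluoromethyl in place of methoxy on an aromatic carbon, and the step was a 4.8-fold higher number from compound 1 to compound 2 (0.68 log units; beyond the scatter). From compound 1 to compound 3 the change is pyridin-2-yl in place of 4-chlorophenyl on a carbonyl carbon, and the step was a 1.4-fold lower number from compound 1 to compound 3 (0.14 log units; within the scatter), so compound 1 and compound 3 cannot be told apart on this read-out.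

Compound 4, `CCCCc1ccc2[nH]c(-c3ccc(C(F)(F)F)cc3)c(/C=N/NC(=O)c3ccccn3)c2c1`, is not yet measured. It differs from compound 3 by trifluoromethyl in place of methoxy on an aromatic carbon. For the measured compounds named here, this is the same change as the one from compound 1 to compound 2: the group leaving, the group entering and the place are the same in both, and the two cores differ only by pyridin-2-yl in place of 4-chlorophenyl on a carbonyl carbon, which on its own moved the number within the scatter.

On that basis the step from compound 3 to compound 4 is expected to be about a 4.7-fold higher number from compound 3 to compound 4 (0.67 log units; beyond the scatter), close to the earlier 4.8-fold higher number from compound 1 to compound 2 (0.68 log units; beyond the scatter), because the change is identical and the core difference a 1.4-fold lower number from compound 1 to compound 3 (0.14 log units; within the scatter) is small. Compound 4 is therefore estimated at 750 nM in this assay, with a plausible range from 300 nM to 1900 nM.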

Compound 4, half-maximal inhibitory concentration: 310 nM
Compound 4: the middle estimate sits 2.4-fold (0.38 log units) above what was measured, within the range that was stated.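

In this assay, trifluoromethyl in place of methoxy gives a 1.9-fold higher number from compound 3 to compound 4 (0.29 log units; within the scatter), and the two instances of this change do not separate, although one step lies beyond the scatter and the other within it: the same change on two cores in this assay, a 4.8-fold higher number (0.68 log units; beyond the scatter) from compound 1 to compound 2 and a 1.9-fold higher number (0.29 log units; within the scatter) from compound 3 to compound 4, 2.5-fold (0.40 log units) apart, within the scatter of two such steps. Pyridin-2-yl in place of 4-chlorophenyl gives a 3.4-fold lower number from compound 2 to compound 4 (0.53 log units; beyond the scatter), and here too the two instances do not separate, again with one step on each side of the scatter: the same change on two cores in this assay, a 1.4-fold lower number (0.14 log units; within the scatter) from compound 1 to compound 3 and a 3.4-fold lower number (0.53 log units; beyond the scatter) from compound 2 to compound 4, 2.5-fold (0.40 log units) apart, within the scatter of two such steps. The four compounds are therefore consistent with each change carrying from one core to the other in this series, but they do not show that the steps are equal, and two cores give no firm size for either step on a further core.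

The compounds shown leave open whether this carry-over holds for other groups in the place of methoxy, such as a nitrile or a dimethylamino group, or for other groups on the carbonyl carbon, such as a morpholine or a carboxylic acid-bearing phenyl. They also leave open whether it survives a change elsewhere on the shared core, for example a longer chain in place of butyl.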